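Heteroaryl swaps on the biaryl of a B1 series

This account rests on a few compounds, and the source may have more. Where it says the series, first, only, none or still open, it means among the compounds named here.

Measured so far, in an assay on CHO cells for displacement of a labelled ligand from B1 bradykinin receptor (Homo sapiens); a lower number here means a stronger inhibitor, a higher number a weaker inhibitor:
- compound 1, `C[C@@H](Nc1nccc(Cl)c1NC(=O)CC#N)c1ccc(-c2cccc(F)c2C(F)(F)F)cc1`: compound 1 gives 1.1 nM
- compound 2, `Cc1noc(-c2c(F)cccc2-c2ccc([C@@H](C)Nc3nccc(Cl)c3NC(=O)CC#N)cc2)n1`: compound 2 gives 0.5 nM
- compound 3, `C[C@@H](Nc1nccc(Cl)c1NC(=O)CC#N)c1ccc(-c2cccc(F)c2-c2nnn(C)n2)cc1`: compound 3 gives 0.5 nM

Compound 3 stands level with compound 2 at the digits recorded, the two together being the lowest of the three numbers; its furthest neighbour is compound 1, a 2.2-fold lower number from compound 1 to compound 3 (0.34 log units; beyond the scatter).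

Compound 4, `Cc1nc(-c2c(F)cccc2-c2ccc([C@@H](C)Nc3nccc(Cl)c3NC(=O)CC#N)cc2)no1`, differs from compound 3 in one place: 5-methyl-1,2,4-oxadiazol-3-yl in place of 2-methyl-2H-tetrazol-5-yl on an aromatic carbon. The new group is the isomer of the ring carried by compound 2, with the methyl and the attachment point exchanged.

Among the compounds with values here, three steps bear on this. Replacing trifluoromethyl by either five-membered ring gave the same modest gain, a 2.2-fold lower number from compound 1 to compound 2 (0.34 log units; beyond the scatter) and a 2.2-fold lower number from compound 1 to compound 3 (0.34 log units; beyond the scatter). Exchanging one ring for the other gave nothing, no change at the digits printed from compound 2 to compound 3 (within the scatter). On that basis a third small heteroaryl at the same position is expected to sit where compound 2 and compound 3 already sit, with no step beyond the scatter in this assay: no change at the digits printed from compound 3 to compound 4 (within the scatter) is the expected outcome. Compound 4 is estimated at 0.5 nM, within 0.25 nM to 1 nM.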

Compound 4, inhibition constant: 0.7 nM
Compound 4: middle estimate off by 1.4-fold (0.15 log units), on the low side; the measured number falls inside the stated range.
By their numbers in this assay, from the lowest: compounds 2, 3, 4 and 1 (each within the scatter of the next, the first and the last beyond it).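

Moving the methyl and the attachment point around the oxadiazole on this aromatic carbon, ortho to a fluoro group, leaves no readable difference in this assay (a 1.4-fold higher number from compound 2 to compound 4 (0.15 log units; within the scatter)), so the two ring isomers cannot be told apart here. A five-membered aromatic ring with 3 hetero atoms also cannot be told apart from the one with 4 hetero atoms (a 1.4-fold higher number from compound 3 to compound 4 (0.15 log units; within the scatter)), which extends the flat picture at this position to a third small heteroaryl. Against trifluoromethyl, however, the new ring stays within the scatter (a 1.6-fold lower number from compound 1 to compound 4 (0.20 log units; within the scatter)), whereas the step to the tetrazole lies beyond it (a 2.2-fold lower number from compound 1 to compound 3 (0.34 log units; beyond the scatter)), so the separation from compound 1 is marginal and is not shared by all three heteroaryl compounds. Nothing available bears on the reason for any of these steps.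

Every group shown at this carbon has no net charge, so it remains open whether a carboxylic acid or an aminomethyl group would stay in the same range. Also open, on these data alone, is what the ring methyl contributes, since all three heteroaryl groups carry one and an unsubstituted 1H-tetrazol-5-yl is not among them.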